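Phenoxy in place of tert-butyl on compound 2

The source may hold more compounds than are shown below. What is called first, only, known or untested is meant among the compounds shown, and "the series" means these compounds.

In a functional assay on HeLa cells (Homo sapiens) for inhibition, read by CCK-8 assay, with a stated time of 72 h (on this read-out lower numbers stand for stronger inhibition and higher numbers for weaker inhibition), compound 1 `CCc1ccc(NS(=O)(=O)c2cccc(CCCCCCNC(=O)/C=C/c3cccnc3)c2)cc1` reads 132 nM and compound 2 `CC(C)(C)c1ccc(NS(=O)(=O)c2cccc(CCCCCCNC(=O)/C=C/c3cccnc3)c2)cc1` reads 1520 nM as the higher of the two numbers. Compound 3 `O=C(/C=C/c1cccnc1)NCCCCCCc1cccc(S(=O)(=O)Nc2ccc(Oc3ccccc3)cc2)c1` differs from compound 2 by phenoxy in place of tert-butyl on an aromatic carbon. Within the data shown here, the only measured step at this place is tert-butyl in place of ethyl (a 12-fold higher number from compound 1 to compound 2 (1.06 log units; beyond the scatter)), so the number responds strongly to the group there, yet that single step gives no rule for phenoxy. A moderate move to a lower number in this assay is expected (a 2.8-fold lower number from compound 2 to compound 3 (0.44 log units; beyond the scatter)). The estimate for compound 3 is 550 nM (expected range 90 nM to 3000 nM).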

Compound 3, half-maximal inhibitory concentration: 262 nM
For compound 3 the middle estimate is 2.1-fold (0.32 log units) above the measured one; the range from low to high includes it.
By their numbers in this assay, from the lowest: compounds 1 and 3 (each within the scatter of the next); then compound 2.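

In this assay, the change to phenoxy gives a 5.8-fold lower number from compound 2 to compound 3 (0.76 log units; beyond the scatter) and so brings a group with more heavy atoms than tert-butyl, plus an aromatic ring, without a higher number at this position. Against ethyl, phenoxy gives a 2.0-fold higher number from compound 1 to compound 3 (0.30 log units; within the scatter), so heavy-atom count alone does not order these three compounds. No measurement on hand accounts for this.

On these data alone, whether the oxygen of phenoxy matters stays open, and a benzyl group would test it. As far as these compounds go, how an amine or a carboxylic acid on this aromatic carbon would read also stays open.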